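The source may hold more compounds than are shown below. What is called first, only, known or untested is meant among the compounds shown, and "the series" means these compounds.

In an ADME assay on PBMC cells (Homo sapiens) for cytotoxicity, read by MTT assay, with a stated time of 72 h, in the presence of a further agent that is not named here (on this read-out lower numbers stand for stronger inhibition and higher numbers for weaker inhibition), compound 1 `COc1ccc(Nc2ccc3ccccc3n2)cc1` gives 70000 nM, the lower of the two numbers in hand. Compound 3 `COc1ccc(Nc2cccnc2)cc1` gives 183000 nM, a higher number beyond the scatter, and for compound 2 `CCc1ccc(Nc2cc(-c3cccc(C(F)(F)F)c3)ccn2)cc1` the entry reads "not determined" (no result reported). The next analogue, compound 4 `Fc1ccc(Nc2ccc3ccccc3n2)cc1`, keeps the core of compound 1 and carries fluoro in place of methoxy on an aromatic carbon, para to a large group: fluoro in place of methoxy on an aromatic carbon. Among the measured compounds shown here, no measured pair isolates this change, so the expectation in this assay rests on compound 1 at 70000 nM: no step beyond the scatter, in either direction. The expected step is a 1.1-fold higher number from compound 1 to compound 4 (0.03 log units; within the scatter). Compound 4 is estimated at 75000 nM, with an expected range of 28000 nM to 170000 nM.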

Compound 4, half-maximal inhibitory concentration: 65000 nM
Compound 4: middle estimate off by 1.2-fold (0.06 log units), on the high side; measured number inside the range.
By their numbers in this assay, from the lowest: compounds 4 and 1 (each within the scatter of the next); then compound 3.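

In this assay, among the compounds shown here, fluoro in place of methoxy on an aromatic carbon, para to a large group, gives a 1.1-fold lower number from compound 1 to compound 4 (0.03 log units; within the scatter), the first pair to isolate this change. On the core of compound 1, this position therefore takes the swap without a step beyond the scatter, although the hydrogen-bond acceptor of the methoxy group leaves with it. Nothing measured here speaks to a cause for this result. Open, from the compounds shown here alone, is how an amine or a longer chain such as ethoxy would read at this position. Also open, going by these compounds, is whether the same change gives a comparable step on the core of compound 3.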